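Fluoro in place of methyl on the core of compound 1

The compounds below may be only part of what the source reports. "The series", "measured", "known", "first", "only" and "open" are said of these compounds alone.

Compound 1 `Cc1cnc(Nc2ccc(S(C)(=O)=O)cc2)nc1Nc1nc2ccc(F)cc2s1`: > 50000 nM
Compound 2 `Cc1cnc(Nc2ccc(S(C)(=O)=O)cc2)nc1Nc1nc2ccccc2s1`: > 50000 nM
Compound 3 `Cc1cnc(Nc2ccc(S(N)(=O)=O)cc2)nc1Nc1nc2ccc(F)cc2s1`: 6980 nM

Of the compounds shown here, three have been measured in a functional assay on PC-3 cells (Homo sapiens) for antiproliferative activity, read by MTT assay, with a stated time of 48 h; a higher number here means a weaker inhibitor, a lower number a stronger inhibitor. For compound 1 the value > 50000 nM is a limit of the assay and not a number. Compound 2 likewise sits at a limit, with > 50000 nM. Compound 3 gives a number, 6980 nM. The set is anchored by the limit of > 50000 nM in this assay, at which 2 of the 3 values shown sit. The step that the two limits leave unreadable from compound 1 to compound 2 is therefore unreadable. The step of an at least 7.1-fold lower number from compound 1 to compound 3 (0.85 log units; beyond the scatter) is the only one with a readable size, and it concerns the amino in place of methyl on a sulfonyl sulfur, a different place in the molecule.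

Compound 4 `CS(=O)(=O)c1ccc(Nc2ncc(F)c(Nc3nc4ccc(F)cc4s3)n2)cc1` differs from compound 1 as fluoro in place of methyl on an aromatic carbon. Within the data shown here, no measured step touches this position, so the two readable values give no guide to its direction. Compound 1 stands at the weak end of the numbers shown, at a limit. The writer expects compound 4 to stay near that limit, with a step of a number no higher from compound 1 to compound 4 (the limit leaves the size open) that lies within the scatter. The estimate for compound 4 is 50000 nM, with a range from 15000 nM to 150000 nM.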

Compound 4, half-maximal inhibitory concentration: > 50000 nM
Compound 4 gave a limit, no number (the forecaster's own chance of this, stated with the estimate: 60%); the middle value sits exactly at the limit.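

In this assay compound 4 gives > 50000 nM, a limit and not a number. Compound 1 also stands at a limit, so no step between compound 1 and compound 4 can be read: the limit of > 50000 nM in this assay, at which 3 of the 4 values shown sit.

The compounds shown leave open whether fluoro in place of methyl on this aromatic carbon changes the activity at all.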